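The source may hold more compounds than are shown below. What is called first, only, known or untested is meant among the compounds shown, and "the series" means these compounds.

Measured so far:
- compound 1, `CCCCCCSC[C@H]1C2CCC(O2)[C@H]1C/C=C\CCCC(=O)O`: 3800 nM in a functional assay on a cell-free system (plasma) for inhibition of thromboxane A2 receptor (Homo sapiens); on this read-out lower numbers stand for stronger inhibition and higher numbers for weaker inhibition
- compound 2, `CCCCSCSCC1C2CCC(O2)C1C/C=C\CCCC(=O)O`: 700 nM in this assay
- compound 3, `CCCCCCS(=O)(=O)CC1C2CCC(O2)C1C/C=C\CCCC(=O)O`: 25000 nM in this assay

Compound 2 stands at the lowest number of the three. Its nearest neighbour is compound 1, whose number is higher by a margin beyond the scatter; compound 3 lies far higher still, also well beyond the scatter. Among the measured compounds shown here, no two of the measured compounds differ in only one place, so no single-point step is available from the measured set.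

Compound 4, `CCCCCCCSCC1C2CCC(O2)C1C/C=C\CCCC(=O)O`, has not yet been measured in this assay. It differs from compound 2 in one place: hexyl in place of butylsulfanyl on a saturated chain carbon bound to a sulfur. The change removes the second sulfur from the side chain and lengthens the carbon chain.

For the measured compounds named here, with no measured step to lean on, the expectation rests on where the measured numbers sit. Compound 2 holds the lowest number; compound 1 gives 3800 nM and compound 3 gives 25000 nM. For compound 4 a move upward from compound 2 is expected, to a weaker result, with the step of a 4.3-fold higher number from compound 2 to compound 4 (0.63 log units; beyond the scatter) expected to lie beyond the scatter. The estimate for compound 4 in this assay is 3000 nM, with a range from 1000 nM to 9000 nM.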

Compound 4, half-maximal inhibitory concentration: 42000 nM
Beside the measured number, compound 4's estimate is 14-fold (1.15 log units) below it; measured number above the stated range.
By their numbers in this assay, from the lowest: compound 2; then compound 1; then compounds 3 and 4 (each within the scatter of the next).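

In this assay, among the compounds shown here, hexyl in place of butylsulfanyl on a saturated chain carbon bound to a sulfur gives a 60-fold higher number from compound 2 to compound 4 (1.78 log units; beyond the scatter), the first single-place step and a large one, so this position does not tolerate the exchange without a marked loss. The change moves two things together: a sulfur with its 1 hydrogen-bond acceptor leaves, and the group grows from 5 heavy atoms to 6, so this one pair cannot assign the step to either the sulfur or the chain length. Nothing on hand bears on why the number rises so steeply.

The compounds shown leave open whether the lower number depends on sulfur itself or on any heteroatom in that place, which butoxy, with oxygen in place of the sulfur, or a butylamino group would address. They also leave open how chain length acts while the sulfur is kept, which a shorter propylsulfanyl or a longer hexylsulfanyl group would show.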